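The source may hold more compounds than are shown below. What is called first, only, known or untested is meant among the compounds shown, and "the series" means these compounds.

Working notes on the series. All three measured compounds share one core and differ only in the group on the urea carbonyl. Compound 1 `O=C(NC1CCN(Cc2ccn(-c3ccc(C(F)(F)F)cc3)c2)CC1)N1CC[C@H](O)C1` gives 125 nM in an assay on HEK293 cells for displacement of a labelled ligand from melanin-concentrating hormone receptor 1 (Homo sapiens) (a higher number here means a weaker inhibitor, a lower number a stronger inhibitor), and compound 2 `O=C(NC1CCN(Cc2ccn(-c3ccc(C(F)(F)F)cc3)c2)CC1)N1CC[C@@H](O)C1` gives 138 nM; the step of a 1.1-fold higher number from compound 1 to compound 2 (0.04 log units; within the scatter) rests on (the fact that compounds 1 and 2 differ only in the configuration as drawn). Compound 3 `O=C(NCC1(O)CCCCC1)NC1CCN(Cc2ccn(-c3ccc(C(F)(F)F)cc3)c2)CC1` gives 44 nM and so holds the lowest number of the three, with the steps of a 2.8-fold lower number from compound 1 to compound 3 (0.45 log units; beyond the scatter) and a 3.1-fold lower number from compound 2 to compound 3 (0.50 log units; beyond the scatter) both modest and beyond the scatter.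

Compound 4 `O=C(O)CC(NC(=O)NC1CCN(Cc2ccn(-c3ccc(C(F)(F)F)cc3)c2)CC1)c1ccccc1` is not yet measured. Against compound 3 the change is 2-carboxy-1-phenylethyl in place of (1-hydroxycyclohexyl)methyl on an amide-type nitrogen. Among the compounds with values here, no measured step touches this exact exchange; the nearest are the two steps into compound 3, which replaced one group on the same carbonyl and moved the number only modestly. The new group is larger and of a different kind than anything measured here, so a reading on the far side of compound 3 is expected rather than a further drop. Compound 4 is estimated at 120 nM, range 40 nM to 400 nM, meaning an expected step of a 2.7-fold higher number from compound 3 to compound 4 (0.44 log units; beyond the scatter).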

Compound 4, half-maximal inhibitory concentration: 412 nM
Estimate against measurement, compound 4: 3.4-fold (0.54 log units) below; the whole stated range lies below it.
By their numbers in this assay, from the lowest: compound 3; then compounds 1 and 2 (each within the scatter of the next); then compound 4.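

In this assay, within the data shown here, the exchange of (1-hydroxycyclohexyl)methyl for 2-carboxy-1-phenylethyl on an amide-type nitrogen gives a 9.4-fold higher number from compound 3 to compound 4 (0.97 log units; beyond the scatter) and is the widest step so far. Against the 3-hydroxypyrrolidin-1-yl pair the new group gives a 3.3-fold higher number from compound 1 to compound 4 (0.52 log units; beyond the scatter) and a 3.0-fold higher number from compound 2 to compound 4 (0.48 log units; beyond the scatter) as its steps, so groups on this carbonyl now move the number in both directions from that pair, not only downward. Nothing measured in the series explains why this group raises the number.

On these data alone, whether the rise follows the carboxylic acid or the phenyl ring of the new group stays open. A plain 1-phenylethyl group or the methyl ester of the acid on the same nitrogen would separate the two.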